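Replacing the Anilino Arm: Expected Cytotoxicity of Compound 4

A few compounds are considered here, and "the series" means these few. Any claim that something is new, unique, unknown or untested is made for them only; others in the source may bear on it.

Three measured compounds share one core. Compound 1 `COc1cc2nc(Nc3ccc(C#N)cc3)nc(Nc3c(F)cc(/C=C/C#N)cc3F)c2cc1OC` gives 6400 nM in an ADME assay on MT4 cells (Homo sapiens) for cytotoxicity, read by MTT assay, with a stated time of 5 days; on this read-out higher numbers stand for lower toxicity in this test and lower numbers for higher toxicity in this test. Compound 2 `COc1cc2nc(Nc3ccc(C#N)cc3)nc(Nc3c(Cl)cc(/C=C/C#N)cc3Cl)c2cc1OC` gives 9920 nM in this assay, the top of the two full numbers shown, though the step of a 1.6-fold higher number from compound 1 to compound 2 (0.19 log units; within the scatter) keeps it within the scatter. Compound 3 `COc1cc2nc(Nc3ccc(C#N)cc3)nc(Nc3c(C)cc(/C=C/C#N)cc3F)c2cc1OC` reaches only the limit > 52000 nM in this assay. The steps of an at least 8.1-fold higher number from compound 1 to compound 3 (0.90 log units; beyond the scatter) and an at least 5.2-fold higher number from compound 2 to compound 3 (0.71 log units; beyond the scatter) both concern the ring bearing the vinyl nitrile, as does (the limit of > 52000 nM in this assay, at which 1 of the 3 values shown sits). Compound 4 `COc1cc2nc(SCC(=O)Nc3cccc(Cl)c3)nc(Nc3c(Cl)cc(/C=C/C#N)cc3Cl)c2cc1OC` differs from compound 2 elsewhere: (((3-chlorophenyl)carbamoyl)methyl)sulfanyl in place of (4-cyanophenyl)amino on an aromatic carbon. Going by the values given here, no measured step touches this position, so no shift beyond the scatter is predicted in either direction. Compound 4 is therefore expected to give 10000 nM, with a range of 3000 nM to 40000 nM. This amounts to an expected 1.0-fold higher number from compound 2 to compound 4 (0.00 log units; within the scatter).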

Compound 4, half-maximal cytotoxic concentration: > 208000 nM
Compound 4: a limit, no number; the forecaster's own chance of this, stated with the estimate: 15%; middle value at least 20-fold (1.31 log units) from the limit.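

In this assay, the aromatic carbon between two ring nitrogen atoms proves to matter: (((3-chlorophenyl)carbamoyl)methyl)sulfanyl in place of (4-cyanophenyl)amino gives an at least 20-fold higher number from compound 2 to compound 4 (1.32 log units; beyond the scatter), which points to lower toxicity in this test. The earlier steps all concerned the ring bearing the vinyl nitrile, so this is the first shift shown at this position. The value for compound 4 is a limit and not a number: the limit of > 208000 nM in this assay, at which 1 of the 4 values shown sits.

The compounds shown leave open which part of the new arm carries this shift. They also leave open whether a simple methylsulfanyl group or an amine at this position would give the same shift.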